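The compounds below may be only part of what the source reports. "The series", "measured", "known", "first", "only" and "open" are said of these compounds alone.

Working notes on the series. Compound 1 `Cc1ccc(S(=O)(=O)c2nc3ccccc3nc2N2CCc3ccccc3C2)cc1` gives > 50000 nM in a functional assay on A549 cells (Homo sapiens) for cytotoxicity, read by MTT assay, with a stated time of 72 h (on this read-out lower numbers stand for stronger inhibition and higher numbers for weaker inhibition), and this is a limit of the assay, not a number. Going by the values given here, compound 2 `O=S(=O)(c1ccccc1)c1nc2ccccc2nc1N1CCC(O)CC1` gives 2060 nM in this assay, the only actual number so far, which makes it the sole anchor for what follows.

Compound 3 `Cc1ccc(S(=O)(=O)c2nc3ccccc3nc2N2CCC(O)CC2)cc1` departs from compound 2 by methyl in place of hydrogen on an aromatic carbon. This is methyl in place of hydrogen on an aromatic carbon, para to a large group, so phenyl becomes 4-methylphenyl.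

Among the compounds with values here, no measured pair differs in one place only, so the size of this change has no direct measure in this assay. With only the reading of compound 2 at 2060 nM to go on, the expectation is no shift beyond the usual scatter, with neither direction favoured. The expected change is a 1.1-fold higher number from compound 2 to compound 3 (0.03 log units; within the scatter), and the range is kept wide to reflect the thin data. The estimated value for compound 3 is 2200 nM, with an expected range of 800 nM to 6500 nM.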

Compound 3, half-maximal inhibitory concentration: 4020 nM
The estimate for compound 3 lay 1.8-fold (0.26 log units) below the measured number; the measured number falls inside the stated range.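

In this assay, going by these compounds alone, the first direct reading of methyl in place of hydrogen on an aromatic carbon, para to a large group, is a 2.0-fold higher number from compound 2 to compound 3 (0.29 log units; within the scatter), so phenyl and 4-methylphenyl cannot be told apart at this position. With 4-methylphenyl held fixed, 4-hydroxypiperidin-1-yl in place of 1,2,3,4-tetrahydroisoquinolin-2-yl gives an at least 12-fold lower number from compound 1 to compound 3 (1.09 log units; beyond the scatter), so among the steps shown, only this one, at the other place on the shared core, lies beyond the scatter. Compound 1 carries a limit of the assay and not a number, so this step gives a bound and not a full size: the limit of > 50000 nM in this assay, at which 1 of the 3 values shown sits.

From the compounds shown here alone, it remains open whether methoxy, chlorine or trifluoromethyl in place of that methyl would move the number beyond the scatter, since a single methyl does not settle what this position tolerates. Going by these compounds, it is also open how much of the large step rests on the hydroxyl itself, a question that plain piperidin-1-yl, morpholin-4-yl or an amine at the same carbon of the piperidine would address.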